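Isopropyl to tert-butyl on a diaryl ether sulfonylurea

The compounds below may be only part of what the source reports. "The series", "measured", "known", "first", "only" and "open" are said of these compounds alone.

Three compounds share a cyanophenyl sulfonylurea core bearing an aryloxy group. Compound 1 `Cc1cccc(Oc2ccc(C#N)cc2S(=O)(=O)NC(=O)NC(C)(C)C)c1` gives 690 nM in a functional assay on HEK293 cells for antagonist activity at thromboxane A2 receptor (Homo sapiens), read by fluorescence and calcium flux; a higher number here means a weaker inhibitor, a lower number a stronger inhibitor. Among the measured compounds shown here, compound 2 `CC(C)(C)NC(=O)NS(=O)(=O)c1cc(C#N)ccc1Oc1ccc(F)cc1` gives 3890 nM in this assay, and the single measured step, a 5.6-fold higher number from compound 1 to compound 2 (0.75 log units; beyond the scatter), concerns the aryloxy group alone. Compound 3 `CC(C)NC(=O)NS(=O)(=O)c1cc(C#N)ccc1Oc1ccc(Cl)cc1` gives 8490 nM in this assay, the highest of the three numbers: compound 2 sits nearest, compound 1 furthest.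

Compound 4 `CC(C)(C)NC(=O)NS(=O)(=O)c1cc(C#N)ccc1Oc1ccc(Cl)cc1` differs from compound 3 by methyl in place of hydrogen on a saturated chain carbon bound to an amide-type nitrogen and two saturated chain carbons. For the measured compounds named here, no measured pair isolates this change; compound 2 and compound 3 differ at two places at once, so their values show only that the tert-butyl compound bearing 4-fluorophenyl sits lower than the isopropyl compound bearing 4-chlorophenyl. On that thin basis, compound 4 is expected to move toward a lower number, though the size is uncertain and could stay within the scatter. The estimated step in this assay is a 2.4-fold lower number from compound 3 to compound 4 (0.38 log units; beyond the scatter). Compound 4 is therefore estimated at 3500 nM, with a range from 1200 nM to 10000 nM.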

Compound 4, half-maximal inhibitory concentration: 5270 nM
Beside the measured number, compound 4's estimate is 1.5-fold (0.18 log units) below it; measured number inside the range.
By their numbers in this assay, from the lowest: compound 1; then compounds 2, 4 and 3 (each within the scatter of the next, the first and the last beyond it).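

The isopropyl to tert-butyl change is now read on its own, with the 4-chlorophenyl group held fixed: in this assay there is a 1.6-fold lower number from compound 3 to compound 4 (0.21 log units; within the scatter), so methyl in place of hydrogen on this saturated chain carbon does not move the number beyond the scatter. With tert-butyl held, chloro in place of fluoro on an aromatic carbon gives a 1.4-fold higher number from compound 2 to compound 4 (0.13 log units; within the scatter), so these two halogens are not told apart here either. By contrast, 4-chlorophenyl in place of 3-methylphenyl gives a 7.6-fold higher number from compound 1 to compound 4 (0.88 log units; beyond the scatter), so among these compounds only the change to 3-methylphenyl on the oxygen separates a compound beyond the scatter.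

Nothing in the data given accounts for these steps. Going by these compounds, it stays open what a cyclohexyl group or a longer chain in place of tert-butyl would do, and whether the isopropyl to tert-butyl step holds with 3-methylphenyl on the oxygen.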